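The compounds below may be only part of what the source reports. "The series", "measured", "known", "first", "only" and "open" are said of these compounds alone.

In a functional assay on the whole organism for inhibition, with Rattus norvegicus as the target, read by paw edema, with stated times of 30 min and 2 h, at a dose of 0.28 mmol/kg by the oral route (on this read-out lower numbers stand for less inhibition and higher numbers for more inhibition at the one dose given (going by the name of the read-out)), compound 3 `NNC(=O)c1nc(-c2ccccc2)n(-c2ccc(S(N)(=O)=O)cc2)n1` gives 53%, and on these numbers compound 3 stands within the scatter of both other measured compounds: compound 1 `NC(=O)c1nc(-c2ccccc2)n(-c2ccc(S(N)(=O)=O)cc2)n1` gives 48% and compound 2 `NS(=O)(=O)c1ccc(-n2nc(C(=O)NC3CCCCC3)nc2-c2ccccc2)cc1` gives 43%. Compound 4 `CC(C)NC(=O)c1nc(-c2ccccc2)n(-c2ccc(S(N)(=O)=O)cc2)n1` differs from compound 3 by isopropyl in place of amino on an amide-type nitrogen. For the measured compounds named here, the steps that bear on this change are the earlier ones at the same amide-type nitrogen: a number 5 percentage points lower from compound 1 to compound 2 (within the scatter), a number 5 percentage points higher from compound 1 to compound 3 (within the scatter) and a number 10 percentage points higher from compound 2 to compound 3 (within the scatter), none of them beyond the scatter. Since hydrogen, cyclohexyl and amino at this position all gave numbers of much the same size, a step of a number 6 percentage points lower from compound 3 to compound 4 (within the scatter) is expected, nothing beyond the scatter. Compound 4 is estimated at 47%, with a range from 35% to 60%.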

Compound 4, a percentage reported as inhibition, in the whole organism at one dose (the size of the read-out at that dose, not a potency): 43%
Beside the measured number, compound 4's estimate is 4 percentage points above it, within the range that was stated.
By their numbers in this assay, from the lowest: compounds 2, 4, 1 and 3 (each within the scatter of the next).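

With isopropyl on the amide-type nitrogen, this assay shows a number 10 percentage points lower from compound 3 to compound 4 (within the scatter) and no change at the digits printed from compound 2 to compound 4 (within the scatter) and a number 5 percentage points lower from compound 1 to compound 4 (within the scatter) as the steps to the new compound. Isopropyl thus joins hydrogen, amino and cyclohexyl as a group that leaves compounds 1 to 4 within the scatter of one another, whether or not the group holds a ring. Nothing given here offers an explanation for these numbers. Going by these compounds, whether a carboxylic acid, a phenyl group or a longer chain on this nitrogen would give a step beyond the scatter stays open.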